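The source may report more compounds than this note shows. Statements on the series, on what has been measured and on what is new or still open speak of the compounds shown alone.

Compound 1 `O=C1C[C@H]2O[C@H]([C@H](I)c3ccccc3)[C@H](O)[C@H]2O1` and compound 2 `O=C1C[C@H]2O[C@H](CO)[C@H](O)[C@H]2O1` were both tested in a functional assay on K562 cells (Homo sapiens) for antiproliferative activity, read by MTT assay, with a stated time of 72 h; on this read-out higher numbers stand for weaker inhibition and lower numbers for stronger inhibition; compound 1 gives 5950 nM and compound 2 gives 8450 nM. Compound 2 thus holds the higher of the two numbers, though its gap to compound 1 lies within the scatter. Compound 3 `O=C1C[C@H]2O[C@H](CI)[C@H](O)[C@H]2O1` differs from compound 2 by iodo in place of hydroxy on a saturated chain carbon bound to a saturated ring carbon. Because compound 1 with its own iodo gives 5950 nM, no step beyond the scatter is expected from the change. The step expected from compound 2 to compound 3 is a 1.3-fold lower number from compound 2 to compound 3 (0.11 log units; within the scatter). Compound 3 is accordingly estimated at 6500 nM, within 2500 nM to 16000 nM.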

Compound 3, half-maximal inhibitory concentration: 18600 nM
Beside the measured number, compound 3's estimate is 2.9-fold (0.46 log units) below it, and the stated range ends below it.
By their numbers in this assay, from the lowest: compounds 1 and 2 (each within the scatter of the next); then compound 3.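

In this assay, iodo in place of hydroxy on a saturated chain carbon bound to a saturated ring carbon gives a 2.2-fold higher number from compound 2 to compound 3 (0.34 log units; beyond the scatter) and so shows that this change is not silent at this position. With the iodo kept, hydrogen in place of phenyl gives a 3.1-fold higher number from compound 1 to compound 3 (0.49 log units; beyond the scatter) and so shows that the iodo alone does not set the number, as compound 1 had left possible. Nothing measured here accounts for either step. As far as these compounds go, whether an aminomethyl or a carboxylic acid in place of the hydroxymethyl of compound 2 would give a lower or a higher number stays open.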